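Acetyl gives way to 4-fluorobenzyl at the assay limit

The compounds below may be only part of what the source reports. "The series", "measured", "known", "first", "only" and "open" are said of these compounds alone.

Of the compounds shown here, two have been tested so far in a functional assay on A549 cells (Homo sapiens) for antiproliferative activity, read by MTT assay, with a stated time of 48 h; on this read-out lower numbers stand for stronger inhibition and higher numbers for weaker inhibition. Compound 1 `Cn1cc(-c2cnc3ccc(NS(=O)(=O)c4ccc(Cl)cc4Cl)nc3c2)cn1` gives > 50000 nM, which is a limit of the assay and not a number. Compound 2 `CC(=O)Nc1nccc2ncc(-c3cnn(C)c3)cc12` gives > 50000 nM, which is also a limit. Both values therefore sit at the limit of > 50000 nM in this assay, at which 2 of the 2 values shown sit, and no measured number is yet available as a starting point.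

Compound 3 `Cn1cc(-c2cnc3ccnc(NCc4ccc(F)cc4)c3c2)cn1` has not been measured. Its structure differs from that of compound 2 by 4-fluorobenzyl in place of acetyl on a nitrogen on an aromatic ring, with 4-fluorobenzyl in place of acetyl on a nitrogen on an aromatic ring. Starting from that limit, a modest move towards stronger inhibition is expected for the step of an at least 2.0-fold lower number from compound 2 to compound 3 (0.30 log units; that floor lies within the scatter), though its size is highly uncertain. Another limit would be no surprise in this assay. The estimate for compound 3 is 25000 nM, with an expected range of 6000 nM to 50000 nM.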

Compound 3, half-maximal inhibitory concentration: 5200 nM
Estimate against measurement, compound 3: 4.8-fold (0.68 log units) above, and the stated range ends above it.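

Replacing acetyl with 4-fluorobenzyl on a nitrogen on an aromatic ring gives an at least 9.6-fold lower number from compound 2 to compound 3 (0.98 log units; beyond the scatter) in this assay and shows that the group at this place can change the read-out. For the compounds shown here, compound 3 also provides the first measured number here, a firm reference for comparing further changes at this nitrogen. As far as these compounds go, compound 2 has only a limit and not a number, so the true size of this step remains unknown because the step can only be stated as a floor: the limit of > 50000 nM in this assay, at which 2 of the 3 values shown sit.

Going by these compounds alone, what the single change cannot separate is the contribution of the fluorine from that of the benzyl group as a whole. From the compounds shown here alone, how a plain benzyl, a longer chain such as 2-phenylethyl or a simple methyl would read out on this nitrogen remains open.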